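Amide aryl group and cytotoxicity: compound 2 to compound 4

The source may report more compounds than this note shows. Statements on the series, on what has been measured and on what is new or still open speak of the compounds shown alone.

Compound 2 `CC(C)n1ncc2c(C(=O)Nc3ccc(F)cc3F)cc(-c3cccs3)nc21` carries a 2,4-difluorophenyl group on an amide-type nitrogen. In an ADME assay on LLC-MK2 cells (Macaca mulatta) for cytotoxicity, read by spectrophotometry and crystal violet staining, with a stated time of 4 days (on this read-out lower numbers stand for higher toxicity in this test and higher numbers for lower toxicity in this test), compound 2 reaches only the assay limit, reported as > 200000 nM, so no number is known for it. Compound 1 `CC(C)n1ncc2c(C(=O)Nc3cccc(C(N)=O)c3)cc(-c3cccs3)nc21`, with 3-carbamoylphenyl in that place, gives 25000 nM in this assay. Among the compounds with values here, the single counted step, an at least 8.0-fold higher number from compound 1 to compound 2 (0.90 log units; beyond the scatter), therefore runs from a number up to a limit. Compound 3 `CC(C)n1ncc2c(C(=O)Nc3ccncn3)cc(-c3ccsc3)nc21` likewise stops at a limit in this assay, > 200000 nM. Within the data shown here, no step to compound 3 is counted; its value only shows that a second amide substituent also sits at the limit. Two of the three values thus share (the limit of > 200000 nM in this assay, at which 2 of the 3 values shown sit).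

Compound 4 `CC(C)n1ncc2c(C(=O)Nc3ccccn3)cc(-c3cccs3)nc21` has not been measured. It differs from compound 2 as follows: pyridin-2-yl in place of 2,4-difluorophenyl on an amide-type nitrogen. Among the measured compounds shown here, the only measured step bearing on this position is an at least 8.0-fold higher number from compound 1 to compound 2 (0.90 log units; beyond the scatter), which shows the amide aryl group can shift the value by at least a modest amount; compound 3, with its own group on the amide-type nitrogen, also sits at the limit. The step from compound 2 to compound 4 is therefore expected to stay within the scatter if a number is returned at all, giving a number no higher from compound 2 to compound 4 (the limit leaves the size open). Compound 4 is thus estimated at 200000 nM, with a range from 60000 nM to 600000 nM, and a real chance that only a limit is reported again.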

Compound 4, half-maximal cytotoxic concentration: > 200000 nM
Compound 4: only a limit was reported; the forecaster's own chance of this, stated with the estimate: 65%; the middle value sits exactly at the limit.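

In this assay compound 4 gives > 200000 nM, which is a limit and not a number. Replacing 3-carbamoylphenyl with pyridin-2-yl on the amide-type nitrogen gives an at least 8.0-fold higher number from compound 1 to compound 4 (0.90 log units; beyond the scatter), so a ring with one hetero atom and one hydrogen-bond acceptor now reaches the limit, as the carbon-only 2,4-difluorophenyl ring did, although the step between compound 2 and compound 4 cannot be read. Among the groups shown on this nitrogen, only 3-carbamoylphenyl in compound 1 gives a number, and the limit is now the common result: the limit of > 200000 nM in this assay, at which 3 of the 4 values shown sit.

Still open, going by these compounds, is whether the carbamoyl group itself sets compound 1 apart, which a phenyl ring carrying a carboxylic acid or an aminomethyl group in its place would help to test. Also open, on these data alone, is how far 2,4-difluorophenyl and pyridin-2-yl differ in this test, as neither compound 2 nor compound 4 gives a number to compare.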